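Boc-Protected Aminomethyl Replacing a Primary Amide

The source may report more compounds than this note shows. Statements on the series, on what has been measured and on what is new or still open speak of the compounds shown alone.

Compound 1 `NC(=O)c1ccccc1NC(=O)c1ccc2ccccc2n1` gives 10 ug/mL in a physicochemical assay for solubility; on this read-out lower numbers stand for lower solubility and higher numbers for higher solubility.
Compound 2 `NC(=O)c1ccc(NC(=O)c2ccc3ccccc3c2)cc1` gives only a limit, < 5 ug/mL, in this assay.

Compound 1 holds the only number shown; the other value sits at the limit of < 5 ug/mL in this assay, at which 1 of the 2 values shown sits. Compound 3 `CC(C)(C)OC(=O)NCc1ccccc1NC(=O)c1ccc2ccccc2n1` is not yet measured. It differs from compound 1 by ((tert-butoxycarbonyl)amino)methyl in place of carbamoyl on an aromatic carbon. Going by the values given here, no measured step in this assay covers such a change, so the expectation rests on compound 1 alone. A modest downward step is expected, a 1.7-fold lower number from compound 1 to compound 3 (0.22 log units; within the scatter), close to the scatter. Compound 3 is therefore estimated at 6 ug/mL, within 2 ug/mL to 25 ug/mL.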

Compound 3, solubility: < 5 ug/mL
Compound 3: only a limit was reported; the forecaster's own chance of this, stated with the estimate: 35%; middle value at least 1.2-fold (0.07 log units) from the limit.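

With ((tert-butoxycarbonyl)amino)methyl in place of carbamoyl at this position, this assay gives an at least 2.0-fold lower number from compound 1 to compound 3 (0.30 log units; that floor lies within the scatter), the first step shown at this position, and it does not point to a higher number. The result for compound 3 is a limit and not a number, so the step gives only a floor: compound 3 is the second compound at that limit: the limit of < 5 ug/mL in this assay, at which 2 of the 3 values shown sit.

From the compounds shown here alone, how far the true value of compound 3 lies from this limit remains open. Also open, going by these compounds, is what an aminomethyl or a carboxylic acid would give on the same aromatic carbon.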